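Swapping an aromatic ring for a saturated one on the urea

The compounds below may be only part of what the source reports. "The series", "measured", "known", "first", "only" and "open" are said of these compounds alone.

Of the compounds shown here, two have been tested in a functional assay on B16-F10 cells (Mus musculus) for cytotoxicity, read by MTT assay, with a stated time of 48 h; on this read-out lower numbers stand for stronger inhibition and higher numbers for weaker inhibition. Compound 1 `COc1cc(CN(C(=O)Nc2ccc(C)cc2)n2cnnc2)cc(OC)c1OC` gives 46800 nM. Compound 2 `O=C(Nc1ccccc1)N(Cc1ccccn1)n1cnnc1` gives 23700 nM, and the two numbers lie within the usual scatter of each other, so neither compound can be called stronger. Compound 3 `O=C(NC1CCCCC1)N(Cc1ccccn1)n1cnnc1` is not yet measured; it differs from compound 2 in one place (cyclohexyl in place of phenyl on an amide-type nitrogen). Going by the values given here, no measured pair shows the effect of such a change here, so the step from compound 2 to compound 3 in this assay is expected to stay within the scatter, a 1.3-fold higher number from compound 2 to compound 3 (0.10 log units; within the scatter). Compound 3 is therefore estimated at 30000 nM, between 10000 nM and 90000 nM.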

Compound 3, half-maximal inhibitory concentration: 35800 nM
For compound 3 the middle estimate is 1.2-fold (0.08 log units) below the measured one, and the stated range covers the measured number.
By their numbers in this assay, from the lowest: compounds 2, 3 and 1 (each within the scatter of the next).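

Putting cyclohexyl in place of phenyl on an amide-type nitrogen gives a 1.5-fold higher number from compound 2 to compound 3 (0.18 log units; within the scatter) in this assay for this pair. This first measured change at this position therefore shows that, in this pair, the aromatic and the saturated ring of six carbons cannot be told apart. No measured information explains this result.

The compounds shown leave open whether an open-chain group such as butyl, or a benzyl group, would give a different number on this nitrogen. They also leave open whether adding a carboxylic acid to the phenyl of compound 2 would move its number beyond the scatter.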